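A few compounds are considered here, and "the series" means these few. Any claim that something is new, unique, unknown or untested is made for them only; others in the source may bear on it.

Measured so far:
compound 1 `COc1cc(-c2cc(/C=C/C(=O)c3ccc(Cl)c(Cl)c3)[nH]n2)cc(OC)c1OC` — 99%
compound 2 `COc1ccc(-c2cc(/C=C/C(=O)c3ccc(N)cc3)[nH]n2)cc1OC` — 99%
compound 3 `COc1cc(C(=O)/C=C/c2cc(-c3cc(OC)c(OC)c(OC)c3)n[nH]2)cc(OC)c1OC` — 99%

In a functional assay on K562 cells (Homo sapiens) for cytotoxicity, read by sulforhodamine B assay, with a stated time of 48 h, tested at 0.01 uM (a lower number here means a stronger effect, a higher number a weaker effect of the compound at the concentration tested), compound 1 gives 99%. Compound 2 gives 99% and compound 3 gives 99%. Compound 1 stands level with both at the digits reported, its nearest neighbour being compound 2 and its furthest compound 3, and in each case the gap lies within the usual scatter, so none of the three can be set apart from the others on these numbers.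

Compound 4 `COc1cc(-c2cc(/C=C/C(=O)c3ccc(F)c(F)c3)[nH]n2)cc(OC)c1OC` has not yet been measured in this assay. It differs from compound 1 in one place: 3,4-difluorophenyl in place of 3,4-dichlorophenyl on a carbonyl carbon

Going by the values given here, no step between two measured compounds that differ in a single place is available, so the size of this change cannot be read from a precedent. What the three measured compounds show is that quite different variations on the shared core all arrive at the same reading at this concentration. On that basis the step of a number 1 percentage points lower from compound 1 to compound 4 (within the scatter) is expected to be none beyond the scatter. Compound 4 is therefore expected to give 98%, with a range from 90% to 100%.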

Compound 4, a percentage reported as activity, at one concentration (the size of the read-out at that concentration, not a potency): 100%
Compound 4: the middle estimate sits 2 percentage points below what was measured; measured number inside the range.
By their numbers in this assay, from the lowest: compounds 1, 2, 3 and 4 (each within the scatter of the next).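

Going by these compounds alone, compound 1 and compound 4 give the first single-place comparison in this set. In this assay, putting 3,4-difluorophenyl in place of 3,4-dichlorophenyl on a carbonyl carbon gives a number 1 percentage points higher from compound 1 to compound 4 (within the scatter), so exchanging the two chlorine atoms for two fluorine atoms at this position does not set the pair apart at this one concentration. Nothing available bears on why the reading holds across this change.

On these data alone, it remains open whether a carboxylic acid or a longer chain on this carbonyl carbon, in place of the halogenated phenyl ring, would shift the reading beyond the scatter. As far as these compounds go, it is also open whether compound 1 and compound 4 would stay level at higher concentrations, where a stronger effect might separate them.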